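Vinyl in Place of Chlorine on the Sulfonamide Aryl

The source may hold more compounds than are shown below. What is called first, only, known or untested is meant among the compounds shown, and "the series" means these compounds.

Measured so far:
compound 1 `O=S(=O)(Nc1ccc(-c2nc3ccccc3o2)cc1)c1cccc(Cl)c1`: 54000 nM
compound 2 `O=S(=O)(Nc1ccc(-c2nc3cc(NS(=O)(=O)c4cccc(O)c4)ccc3o2)cc1)c1cccc(O)c1`: 17000 nM
compound 3 `O=S(=O)(Nc1ccc(-c2nc3cc(NS(=O)(=O)c4ccccc4F)ccc3o2)cc1)c1ccccc1F`: 57000 nM

In an assay on cells for inhibition of HSP60/HSP10 (Homo sapiens), with a stated time of 60 min (on this read-out higher numbers stand for weaker inhibition and lower numbers for stronger inhibition), compound 1 gives 54000 nM, the second highest of the three numbers. Compound 3 sits closest, within the usual scatter, so the two cannot be told apart. Compound 2 lies furthest away, with a lower number that is beyond the scatter.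

The step to compound 4 `C=Cc1ccc(S(=O)(=O)Nc2ccc(-c3nc4ccccc4o3)cc2)cc1` changes only the aryl on the sulfonyl sulfur: 4-vinylphenyl in place of 3-chlorophenyl on a sulfonyl sulfur. Going by the values given here, no pair among the measured compounds shows a change of this kind, so there is nothing to copy. A change confined to one substituent on that ring is expected to move the number little, in neither clear direction beyond the scatter. Compound 4 is therefore estimated at 45000 nM, with a range from 15000 nM to 130000 nM. That estimate means a step of a 1.2-fold lower number from compound 1 to compound 4 (0.08 log units; within the scatter), small and not expected to pass the scatter.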

Compound 4, half-maximal inhibitory concentration: > 100000 nM
Compound 4 ended at the assay's limit; the forecaster's own chance of this, stated with the estimate: 25%; at least 2.2-fold (0.34 log units) between middle value and limit.
By their numbers in this assay, from the lowest: compound 2; then compounds 1 and 3 (each within the scatter of the next). At a limit, above all of these: compound 4.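

Compound 4 reads as a limit of the assay, not as a number: the limit of > 100000 nM in this assay, at which 1 of the 4 values shown sits. In this assay, 4-vinylphenyl in place of 3-chlorophenyl on a sulfonyl sulfur gives an at least 1.8-fold higher number from compound 1 to compound 4 (0.26 log units; that floor lies within the scatter), so the true gap has no known upper end, although its floor alone does not pass the scatter. This is the first single change shown at this position, and it brings no lower number.

From the compounds shown here alone, whether an aryl carrying an amine or a carboxylic acid here would lower the number remains open. Also open, going by these compounds, is whether plain phenyl would read closer to compound 1 or to compound 4.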